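A Bromine Added to the Ring System of Compound 1

The compounds below may be only part of what the source reports. "The series", "measured", "known", "first", "only" and "open" are said of these compounds alone.

Compound 1 `O=C1C(O)=C(C(c2ccc([N+](=O)[O-])cc2)c2c[nH]c3ccccc23)C(=O)c2ccccc21` is the weakest of three compounds measured in a functional assay on ECa-109 cells (Homo sapiens) for cytotoxicity, read by MTT assay, with a stated time of 48 h (a higher number here means a weaker inhibitor, a lower number a stronger inhibitor), where compound 1 gives 60900 nM. Compound 2 `COc1ccc(C(C2=C(O)C(=O)c3ccccc3C2=O)c2c[nH]c3ccccc23)cc1Br` gives 11800 nM and compound 3 `O=C1C(O)=C(C(c2cccs2)c2c[nH]c3ccccc23)C(=O)c2ccccc21` gives 12100 nM. Both measured steps from compound 1 change the aryl group bound to the saturated chain carbon: a 5.2-fold lower number from compound 1 to compound 2 (0.71 log units; beyond the scatter) and a 5.0-fold lower number from compound 1 to compound 3 (0.70 log units; beyond the scatter), while compound 2 and compound 3 are within the scatter of each other, with a 1.0-fold higher number from compound 2 to compound 3 (0.01 log units; within the scatter).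

Compound 4 `O=C1C(O)=C(C(c2ccc([N+](=O)[O-])cc2)c2c[nH]c3ccc(Br)cc23)C(=O)c2ccccc21` differs from compound 1 elsewhere: bromo in place of hydrogen on an aromatic carbon, that is, 1H-indol-3-yl becomes 5-bromo-1H-indol-3-yl. Within the data shown here, none of the measured steps touches that part of the shared core, so none bears on this change, and the data give no direction for it. Compound 4 is therefore expected to stay close to compound 1, with a 1.4-fold lower number from compound 1 to compound 4 (0.13 log units; within the scatter) as an estimate of no step beyond the scatter. The estimated value for compound 4 in this assay is 45000 nM, within a range from 15000 nM to 150000 nM.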

Compound 4, half-maximal inhibitory concentration: 16900 nM
Compound 4: the middle estimate sits 2.7-fold (0.43 log units) above what was measured, and the stated range covers the measured number.
By their numbers in this assay, from the lowest: compounds 2, 3 and 4 (each within the scatter of the next); then compound 1.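

In this assay, the change from 1H-indol-3-yl to 5-bromo-1H-indol-3-yl gives a 3.6-fold lower number from compound 1 to compound 4 (0.56 log units; beyond the scatter), so this part of the shared core also affects the number, not only the aryl group on the saturated chain carbon. Compound 4 keeps the 4-nitrophenyl group of compound 1. The only difference between the two is a single bromo in place of hydrogen on an aromatic carbon. No measurement shown here explains why this substitution lowers the number.

The compounds shown leave open whether a chlorine, a methoxy group or an amine on the same aromatic carbon would lower the number as bromo does. They also leave open whether bromo would give a similar step in compounds carrying thiophen-2-yl or 3-bromo-4-methoxyphenyl on the chain carbon.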